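The source may hold more compounds than are shown below. What is called first, only, known or untested is meant among the compounds shown, and "the series" means these compounds.

Measured so far:
Compound 1 `CCC(=O)N(c1ccc(Cl)cc1)C1CCCC1N(C)C` gives 0.2 mg/kg in a functional assay on the whole organism for antagonist activity, with Mus musculus as the target; a higher number here means that more compound is needed for the effect, a lower number that less compound is needed.
Compound 2 `CCC(=O)N(c1cccc(F)c1)C1CCCC1N(C)C` gives 0.6 mg/kg in this assay.
Compound 3 `CCC(=O)N(c1ccc(F)cc1)C1CCCC1N(C)C` gives 0.08 mg/kg in this assay.

Compound 4 `CCC(=O)N(c1cccc(Cl)c1)C1CCCC1N(C)C` has not yet been measured in this assay. It differs from compound 2 by chloro in place of fluoro on an aromatic carbon. The same kind of change links compound 3 to compound 1, (chloro in place of fluoro on an aromatic carbon), though there the entering group sits para to a large group, whereas in compound 4 it sits meta to a large group. That earlier step gave a 2.5-fold higher number from compound 3 to compound 1 (0.40 log units; beyond the scatter). How the core of compound 2 differs from that of compound 3 is not broken down here; compound 2 gives the highest number of the three. The expectation for compound 4 rests on a 2.5-fold higher number from compound 3 to compound 1 (0.40 log units; beyond the scatter). A step of similar size is expected to follow, a 2.2-fold higher number from compound 2 to compound 4 (0.34 log units; beyond the scatter), with wider uncertainty given the different place. Compound 4 is estimated at 1.3 mg/kg, likely between 0.5 mg/kg and 3.5 mg/kg.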

Compound 4, dose for half-maximal effect: 0.2 mg/kg
Beside the measured number, compound 4's estimate is 6.5-fold (0.81 log units) above it; measured number outside the range, below it.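

In this assay, chloro in place of fluoro on an aromatic carbon gave a 3.0-fold lower number from compound 2 to compound 4 (0.48 log units; beyond the scatter), so the step seen on the other core did not carry over in direction, and the two steps differ: the same change on two cores in this assay, a 2.5-fold higher number (0.40 log units; beyond the scatter) from compound 3 to compound 1 and a 3.0-fold lower number (0.48 log units; beyond the scatter) from compound 2 to compound 4, 7.5-fold (0.88 log units) apart, beyond the scatter of two such steps

For these two pairs, then, the result of this change on the core of compound 3 gave no reliable guide to its result on the core of compound 2. The data do not show why the steps run in opposite directions, and two pairs give no rule for any other core.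

The compounds shown leave open how a bromo or a trifluoromethyl group would fare on the same aromatic carbon. They also leave open whether the opposite steps would persist with a longer chain on the amide carbonyl.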